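Sulfonyl series: nitro removal, then cyclohexyl swap

The compounds below may be only part of what the source reports. "The series", "measured", "known", "first", "only" and "open" are said of these compounds alone.

Compound 1 `O=C1c2ccccc2N(Cc2ccc([N+](=O)[O-])cc2)S(=O)(=O)N1Cc1ccc([N+](=O)[O-])cc1` gives 53000 nM in a functional assay on MRC5 cells (Homo sapiens); a lower number here means that less compound is tolerated, a higher number that more compound is tolerated. Compound 2 `O=C1c2ccccc2N(Cc2ccc([N+](=O)[O-])cc2)S(=O)(=O)N1Cc1ccccc1` reaches only a limit of this assay, reported as > 59000 nM. For the measured compounds named here, compound 2 thus stands as a floor rather than a number, with its step of an at least 1.1-fold higher number from compound 1 to compound 2 (0.04 log units; that floor lies within the scatter) the single measured step in the set, resting on (the limit of > 59000 nM in this assay, at which 1 of the 2 values shown sits), so its true size remains open. Compound 3 `O=C1c2ccccc2N(CC2CCCCC2)S(=O)(=O)N1Cc1ccccc1` differs from compound 2 by cyclohexyl in place of 4-nitrophenyl on a saturated chain carbon bound to a sulfonamide nitrogen in a ring. Going by the values given here, the one measured step bears on this only loosely: both changes take a nitro group out of a benzyl arm, and the measured one has a floor that lies within the scatter. For compound 3 the expectation is therefore no step beyond the scatter, a step that the limit leaves unreadable from compound 2 to compound 3 being the estimated shift. Compound 3 is estimated at 60000 nM, between 30000 nM and 120000 nM, with a real chance that this assay again reports only a limit.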

Compound 3, half-maximal cytotoxic concentration: > 65000 nM
Compound 3 ended at the assay's limit; the forecaster's own chance of this, stated with the estimate: 55%; middle value at least 1.0-fold (0.03 log units) from the limit.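

Compound 2 and compound 3 both stand at limits of this assay, so no step can be read between them. The compounds shown leave open whether cyclohexyl in place of 4-nitrophenyl shifts the half-maximal cytotoxic concentration at all, and in which direction.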